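Swapping Chloro for Cyano in Compound 2

This account rests on a few compounds, and the source may have more. Where it says the series, first, only, none or still open, it means among the compounds named here.

Within the data shown here, compound 2 `Cc1ccsc1CN(C(=O)Nc1cccc(Cl)c1)n1cnnc1` is the only compound in this small set for which a functional assay on DU-145 cells (Homo sapiens) for cytotoxicity, read by MTT assay, with a stated time of 48 h (a higher number here means a weaker inhibitor, a lower number a stronger inhibitor), returns a number: in this assay compound 2 gives 20400 nM. Its parent, compound 1 `Cc1ccsc1CN(C(=O)Nc1ccccc1)n1cnnc1`, carries hydrogen where compound 2 carries chloro. In this assay compound 1 reaches only the limit of the assay, > 50000 nM, and no number. Compound 1 thus sits at the limit of > 50000 nM in this assay, at which 1 of the 2 values shown sits. Among the measured compounds shown here, the one measured step, an at least 2.4-fold lower number from compound 1 to compound 2 (0.38 log units; beyond the scatter), therefore reads as a gain whose full size is not known.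

Compound 3 `Cc1ccsc1CN(C(=O)Nc1cccc(C#N)c1)n1cnnc1` differs from compound 2 as follows: cyano in place of chloro on an aromatic carbon. For the measured compounds named here, no measured step bears directly on a cyano for chloro exchange; the only step measured, an at least 2.4-fold lower number from compound 1 to compound 2 (0.38 log units; beyond the scatter), concerns chloro entering in place of hydrogen, not what replaces chloro. Since compound 2 already lies close to the limit, a change of that size in the weakening direction would put compound 3 at the limit, while a change of that size in the strengthening direction would still leave it weak. For compound 3 the step of a 1.2-fold higher number from compound 2 to compound 3 (0.09 log units; within the scatter) is therefore expected to be small. In this assay compound 3 is estimated at 25000 nM, between 8000 nM and 60000 nM.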

Compound 3, half-maximal inhibitory concentration: 31000 nM
Compound 3: middle estimate off by 1.2-fold (0.09 log units), on the low side; the measured number falls inside the stated range.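

The exchange of chloro for cyano on an aromatic carbon, meta to a large group, gives a 1.5-fold higher number from compound 2 to compound 3 (0.18 log units; within the scatter), so in this assay these two groups cannot be told apart at this place. Among these compounds, this is the first sign that the reading at this position is not tied to chloro alone, although two groups are a narrow basis and the claim reaches no further than compound 2 and compound 3. Measured against hydrogen, cyano gives an at least 1.6-fold lower number from compound 1 to compound 3 (0.20 log units; that floor lies within the scatter), so unlike the chloro step, this floor alone does not establish a gain over the parent, and the true size of the step stays unknown because compound 1 reaches only a limit of the assay: the limit of > 50000 nM in this assay, at which 1 of the 3 values shown sits.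

What the compounds shown leave open is whether an amine, a carboxylic acid or a methoxy group at this same place would read like chloro and cyano or would move the number clearly away from theirs. Also open, on these data alone, is whether the match between chloro and cyano would hold with either group placed elsewhere on that ring of the shared core.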